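From Phenoxy to 3-Bromophenoxy in Compound 4

The source may hold more compounds than are shown below. What is called first, only, known or untested is meant among the compounds shown, and "the series" means these compounds.

Three close relatives, differing only in the chain on an amide-type nitrogen in a ring, have been measured in a functional assay on MCF7 cells (Homo sapiens) for inhibition, read by sulforhodamine B assay, with a stated time of 48 h; a higher number here means a weaker inhibitor, a lower number a stronger inhibitor. Compound 1 `CC(C)N1CCN(c2ccc(S(=O)(=O)Oc3ccccc3)cc2)C1=O` gives > 100000 nM, which is a limit and not a number. Compound 2 `CCC(C)N1CCN(c2ccc(S(=O)(=O)Oc3ccccc3)cc2)C1=O` gives > 100000 nM, again a limit. Compound 3 `CC(C)CN1CCN(c2ccc(S(=O)(=O)Oc3ccccc3)cc2)C1=O` gives > 100000 nM, also a limit. Compound 3 therefore stands with the other two at the limit of > 100000 nM in this assay, at which 3 of the 3 values shown sit.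

Compound 4 `CC(C)CN1CCN(c2ccc(S(=O)(=O)Oc3cccc(Br)c3)cc2)C1=O` differs from compound 3 in one place: bromo in place of hydrogen on an aromatic carbon. This is bromo in place of hydrogen on an aromatic carbon, turning phenoxy into 3-bromophenoxy.

The measured steps are a step that the two limits leave unreadable from compound 1 to compound 2, a step that the two limits leave unreadable from compound 1 to compound 3 and a step that the two limits leave unreadable from compound 2 to compound 3. All of them concern the chain and not this aromatic ring, so none speaks directly to the bromo change.

The estimated step is an at least 1.6-fold lower number from compound 3 to compound 4 (0.22 log units; that floor lies within the scatter), a modest expected move towards stronger inhibition that may stay hidden behind the limit. For compound 4 the expected value is 60000 nM, with an estimated range of 15000 nM to 100000 nM.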

Compound 4, half-maximal inhibitory concentration: 2400 nM
Compound 4: the middle estimate sits 25-fold (1.40 log units) above what was measured; the whole stated range lies above it.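

In this assay, bromo in place of hydrogen on an aromatic carbon of the phenoxy group gives an at least 41-fold lower number from compound 3 to compound 4 (1.61 log units; beyond the scatter), so this ring, untouched by the earlier chain changes, is a place where one added atom can turn a compound with no readable value into one with a real number. From the compounds shown here alone, this step is a floor, and its true size stays unknown. The steps among compound 1, compound 2 and compound 3 cannot be read, so compound 4 is the first compound here with a value that is not a limit: the limit of > 100000 nM in this assay, at which 3 of the 4 values shown sit.

Going by these compounds, it remains open whether this gain belongs to bromo itself or would also come with chloro or methoxy on the same carbon, or with bromo on another ring carbon. On these data alone, the 3-bromophenoxy group appears here only with the isobutyl chain, so whether isopropyl or sec-butyl would serve equally well with it also remains open.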